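Chloro for methylsulfanyl on the monophosphate core

The compounds below may be only part of what the source reports. "The series", "measured", "known", "first", "only" and "open" are said of these compounds alone.

Measured compounds:
compound 1, `CSc1nc(N)c2ncn(C3C(O)C(O)[C@@]4(COP(=O)(O)OP(=O)(O)OP(=O)(O)O)C[C@@H]34)c2n1`: 23 nM
compound 2, `CSc1nc(N)c2ncn([C@H]3[C@H](O)[C@H](O)[C@@]4(COP(=O)(O)O)C[C@@H]34)c2n1`: 590 nM
compound 3, `Nc1nc(Cl)nc2c1ncn2C1C(O)C(O)[C@@]2(COP(=O)(O)OP(=O)(O)OP(=O)(O)O)C[C@@H]12`: 7 nM

All numbers come from an assay on cells with P2Y purinoceptor 1 (Homo sapiens) as the target, read by inositol phosphate accumulation; a higher number here means that more compound is needed for the effect, a lower number that less compound is needed. Compound 1 gives 23 nM and compound 3 gives 7 nM; the change between them, (chloro in place of methylsulfanyl on an aromatic carbon), made the step of a 3.3-fold lower number from compound 1 to compound 3 (0.52 log units; beyond the scatter). Compound 2 gives 590 nM, the highest of the three; how its core differs from the core of compound 1 is not broken down here. Compound 4, `Nc1nc(Cl)nc2c1ncn2[C@H]1[C@H](O)[C@H](O)[C@@]2(COP(=O)(O)O)C[C@@H]12`, carries the same change on the core of compound 2: chloro in place of methylsulfanyl on an aromatic carbon. With one prior case to lean on, the step from compound 2 to compound 4 is expected to be a 3.3-fold lower number from compound 2 to compound 4 (0.52 log units; beyond the scatter), resting on a 3.3-fold lower number from compound 1 to compound 3 (0.52 log units; beyond the scatter). Compound 4 is therefore estimated at 180 nM, most likely between 80 nM and 450 nM.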

Compound 4, half-maximal effective concentration: 1890 nM
Beside the measured number, compound 4's estimate is 11-fold (1.02 log units) below it; the measured number lies above the stated range.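

On the core of compound 2, chloro in place of methylsulfanyl gives a 3.2-fold higher number from compound 2 to compound 4 (0.51 log units; beyond the scatter) in this assay, so the direction seen on the core of compound 1 does not carry over. Within the data shown here, the two cores therefore do not respond alike to this change: the same change on two cores in this assay, a 3.3-fold lower number (0.52 log units; beyond the scatter) from compound 1 to compound 3 and a 3.2-fold higher number (0.51 log units; beyond the scatter) from compound 2 to compound 4, 11-fold (1.02 log units) apart, beyond the scatter of two such steps This shows that the step on one core cannot be used to estimate the step on the other, but with only two pairs it does not show which difference between the cores goes with the reversal.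

Still open, from the compounds shown here alone, is whether a diphosphate chain would follow the core of compound 1 or that of compound 2. Also open, going by these compounds, is how an amine or an ethylsulfanyl group on that aromatic carbon would behave on each core.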